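One Added Chloro on a Shared Core

The source may report more compounds than this note shows. Statements on the series, on what has been measured and on what is new or still open speak of the compounds shown alone.

In a functional assay on DU-145 cells (Homo sapiens) for antiproliferative activity, read by MTT assay, with a stated time of 48 h (on this read-out higher numbers stand for weaker inhibition and lower numbers for stronger inhibition), compound 1 `O=C1NC2(C3=C(C(=O)C4C=CC=CC4C3=O)c3ccccc32)c2ccccc21` gives 2180 nM. Compound 2 `O=C1NC2(C3=C(C(=O)C4C=CC=CC4C3=O)c3ccccc32)c2cc(Cl)c(Cl)cc21` gives 2130 nM, which lies within the scatter of the value for compound 1, so the two stand level. Compound 3 `O=C1NC2(C3=C(C(=O)C4C=CC=CC4C3=O)c3cc(Cl)ccc32)c2ccccc21` has not yet been measured. It differs from compound 1 by chloro in place of hydrogen on an aromatic carbon. Within the data shown here, no measured pair shows this single change alone, so no step beyond the scatter is expected in this assay. The expected size of the step is a 1.2-fold lower number from compound 1 to compound 3 (0.08 log units; within the scatter). For compound 3, the estimated value is 1800 nM, within an expected range of 750 nM to 4000 nM.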

Compound 3, half-maximal inhibitory concentration: 1680 nM
The estimate for compound 3 lay 1.1-fold (0.03 log units) above the measured number; the measured number falls inside the stated range.
By their numbers in this assay, from the lowest: compounds 3, 2 and 1 (each within the scatter of the next).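

Chloro in place of hydrogen on this aromatic carbon, meta to a fused ring and para to a fused ring, is now seen alone: a 1.3-fold lower number from compound 1 to compound 3 (0.11 log units; within the scatter) in this assay. Among these compounds, compound 3 therefore stands level with compound 1, and this position accepts a chlorine atom with no step that can be read beyond the scatter. No measurement at hand offers an explanation for this result.

Going by these compounds, whether a methoxy group or an amine on this same carbon would give a step beyond the scatter remains open.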